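Swapping Ethyl for Formyl on a Shared Core

The source may hold more compounds than are shown below. What is called first, only, known or untested is meant among the compounds shown, and "the series" means these compounds.

Of the compounds shown here, two have been measured in a functional assay on IGROV-1 cells (Homo sapiens) for inhibition, read by sulforhodamine B assay, with a stated time of 48 h, tested at 10 uM; on this read-out higher numbers stand for more inhibition at the one concentration tested (going by the name of the read-out) and lower numbers for less inhibition. Compound 1, `O=Cc1ccc(-c2cn3ccnc3c(-c3ccc4ncn(C5CCCCC5)c4c3)n2)cc1`, gives 21.3% in this assay. Compound 2, `CCc1ccc(-c2cn3ccnc3c(-c3ccc4ncn(Cc5ccccc5)c4c3)n2)cc1`, gives 25%. The two numbers lie within the usual scatter of each other, so compound 2 cannot be set apart from compound 1 on these data; they stand together at a modest level of inhibition at the single concentration tested.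

Compound 3, `O=Cc1ccc(-c2cn3ccnc3c(-c3ccc4ncn(Cc5ccccc5)c4c3)n2)cc1`, has not yet been measured. It differs from compound 2 in one place: formyl in place of ethyl on an aromatic carbon. Among the compounds with values here, no pair of measured compounds shows the effect of this change on its own, since compound 1 carries the formyl group on a different version of the shared core. Within the data shown here, what is known is that the only two numbers available differ by less than the scatter.

Among the measured compounds shown here, with no measured step to lean on, the change from compound 2 to compound 3 is expected to give a step of a number 2 percentage points lower from compound 2 to compound 3 (within the scatter), that is, nothing beyond the scatter in either direction. Compound 3 is therefore expected to give 23% in this assay, with a range from 8% to 40%.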

Compound 3, a percentage reported as inhibition, at one concentration (the size of the read-out at that concentration, not a potency): 21.3%
Compound 3: middle estimate off by 1.7 percentage points, on the high side, within the range that was stated.
By their numbers in this assay, from the lowest: compounds 1, 3 and 2 (each within the scatter of the next).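

The swap of 4-ethylphenyl to 4-formylphenyl can now be read on its own, with only this one place differing: a number 3.7 percentage points lower from compound 2 to compound 3 (within the scatter) in this assay on the shared core. At this place on the aromatic ring, para to a large group, ethyl and formyl therefore cannot be told apart on this read-out, even though one group is made of carbon alone and the other brings in a carbonyl oxygen. Compound 3 also opens a second single-place comparison, benzyl in place of cyclohexyl on an aromatic nitrogen with the formyl group held fixed, and no change at the digits printed from compound 1 to compound 3 (within the scatter) shows that these two groups cannot be separated here either, while no measurement at hand offers an explanation for either result.

From the compounds shown here alone, whether any group at the ring carbon can move the number beyond the scatter stays open, and a carboxylic acid or an amine there would test this more sharply than formyl or ethyl did. On the aromatic nitrogen, a longer chain in place of benzyl or cyclohexyl poses the same open question.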